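This account rests on a few compounds, and the source may have more. Where it says the series, first, only, none or still open, it means among the compounds named here.

Values in a functional assay on HCT-116 cells (Homo sapiens) for inhibition, read by sulforhodamine B assay, with a stated time of 48 h, tested at 50 uM (on this read-out lower numbers stand for less inhibition of growth and higher numbers for more inhibition of growth at the one concentration tested), for the series so far

compound 1 `COc1ccc(/C=C/C(=O)/C=C/c2ccc(OCc3cn(CCCCOc4cc(=O)oc5ccccc45)nn3)c(OC)c2)cc1OC` gives 55%
compound 2 `COc1cccc(/C=C/C(=O)/C=C/c2ccc(OCc3cn(CCOc4cc(=O)oc5ccccc45)nn3)c(OC)c2)c1` gives 70%
compound 3 `COc1cccc(/C=C/C(=O)/C=C/c2ccc(OCc3cn(CCCOc4cc(=O)oc5ccccc45)nn3)c(OC)c2)c1` gives 55%

Compound 2 stands highest of the three, and both compound 1 and compound 3 lie lower by more than the scatter. The next compound to be read is compound 4 `COc1cc(/C=C/C(=O)/C=C/c2ccco2)ccc1OCc1cn(CCOc2cc(=O)oc3ccccc23)nn1`, which carries furan-2-yl in place of 3-methoxyphenyl on a double-bonded chain carbon bound to a double-bonded chain carbon. Among the measured compounds shown here, no measured pair shows this exchange or any other single change, so the direction in this assay is not established by the data. The expectation starts from compound 2 at 70% and leans modestly toward the lower level of the other two compounds, with a wide margin. The expected step is a number 10 percentage points lower from compound 2 to compound 4 (within the scatter), an estimated fall that is not clearly beyond the scatter. For compound 4 the estimate is 60%, with an expected range from 42% to 78%.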

Compound 4, percent growth inhibition at one concentration: 72%
Compound 4: middle estimate off by 12 percentage points, on the low side, within the range that was stated.
By their numbers in this assay, from the lowest: compounds 1 and 3 (each within the scatter of the next); then compounds 2 and 4 (each within the scatter of the next).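

In this assay, among the compounds shown here, the first exchange in one place reads a number 2 percentage points higher from compound 2 to compound 4 (within the scatter), with furan-2-yl in place of 3-methoxyphenyl on a double-bonded chain carbon bound to a double-bonded chain carbon. This read-out therefore does not separate the two groups at this position, although the ring changes from six-membered carbon only to five-membered with 1 hetero atom, and the group shrinks from 8 heavy atoms to 5. Nothing available bears on why the two groups read alike.

As far as these compounds go, whether thiophen-2-yl or pyridin-3-yl at the same place would also stay level with furan-2-yl remains open. Also open, from the compounds shown here alone, is whether furan-2-yl would give the same result on the longer chain of compound 3.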